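Benzyl swap on a compound resting at the limit

The source may hold more compounds than are shown below. What is called first, only, known or untested is meant among the compounds shown, and "the series" means these compounds.

Measured in a functional assay on MCF cells (Homo sapiens) for antiproliferative activity, with a stated time of 72 h; a lower number here means a stronger inhibitor, a higher number a weaker inhibitor:
Compound 1 `OC[C@H]1O[C@@H](n2cnc3c(NCc4ccccc4Br)ncnc32)[C@H](O)[C@@H]1O`: > 166000 nM, a limit
Compound 2 `OC[C@H]1O[C@@H](n2cnc3c(NCc4ccc(F)cc4Cl)ncnc32)[C@H](O)[C@@H]1O`: > 166000 nM, a limit

Compound 2 gives no number in this assay, only the limit > 166000 nM. Both measured compounds rest on (the limit of > 166000 nM in this assay, at which 2 of the 2 values shown sit). Compound 3 `Cc1cccc(CNc2ncnc3c2ncn3[C@@H]2O[C@H](CO)[C@@H](O)[C@H]2O)c1O` differs from compound 2 by one change: 2-hydroxy-3-methylphenyl in place of 2-chloro-4-fluorophenyl on a saturated chain carbon bound to a nitrogen on an aromatic ring. Within the data shown here, the only measured step that bears on it is a step that the two limits leave unreadable from compound 1 to compound 2, so it offers no size to carry over. With no readable step to build on, no firm direction can be expected in this assay, and compound 3 is expected to stay close to the same limit. The estimated change is an at least 1.0-fold lower number from compound 2 to compound 3 (0.01 log units; that floor lies within the scatter). Compound 3 is estimated at 160000 nM, with an expected range of 40000 nM to 300000 nM.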

Compound 3, half-maximal inhibitory concentration: 6900 nM
Compound 3: the middle estimate sits 23-fold (1.37 log units) above what was measured, and the stated range ends above it.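

In this assay, the group on a saturated chain carbon bound to a nitrogen on an aromatic ring can move the result, which the unreadable step between the two halogenated compounds could not show. From the compounds shown here alone, the change to 2-hydroxy-3-methylphenyl gives an at least 24-fold lower number from compound 2 to compound 3 (1.38 log units; beyond the scatter), and the same group gives an at least 24-fold lower number from compound 1 to compound 3 (1.38 log units; beyond the scatter); both are floors, so the full size of each step stays unknown. Compound 3 alone gives a number, while the other two compounds stay at a limit: the limit of > 166000 nM in this assay, at which 2 of the 3 values shown sit.

The hydroxy and methyl groups enter together, and the loss of the halogens comes with them, so the compounds shown do not say which part of the change matters. A methoxy group in place of the hydroxy group, or a hydroxy group without the methyl group, remains an open case.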